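Notes on compound 2 and its phenyl analogue compound 4

The compounds below may be only part of what the source reports. "The series", "measured", "known", "first", "only" and "open" are said of these compounds alone.

Measured so far:
compound 1 `Oc1cccc(-c2cc(-c3ccc(Cl)cc3)nc(-c3cccs3)c2)c1`: 11600 nM
compound 2 `Oc1cccc(-c2cc(-c3cccc(Cl)c3)nc(-c3cccs3)c2)c1`: 2650 nM
compound 3 `Oc1ccc(-c2cc(-c3ccccn3)nc(-c3ccccc3Cl)c2)cc1`: "not determined" (no result reported)

Going by the values given here, in a functional assay on DU-145 cells (Homo sapiens) for cytotoxicity, read by CCK-8 assay and cell counting, with a stated time of 2 days (a lower number here means a stronger inhibitor, a higher number a weaker inhibitor), compound 2 gives 2650 nM, the lowest of the two numbers recorded; compound 1 gives 11600 nM, and the only measured step is a 4.4-fold lower number from compound 1 to compound 2 (0.64 log units; beyond the scatter). Compound 3 carries no number in this assay, its entry being "not determined" (no result reported). Compound 4 `Oc1cccc(-c2cc(-c3ccccc3)nc(-c3cccc(Cl)c3)c2)c1` derives from compound 2 by a single change: phenyl in place of thiophen-2-yl on an aromatic carbon. Among the compounds with values here, no measured pair isolates this change; the one measured step concerns 3-chlorophenyl in place of 4-chlorophenyl and says nothing about thiophen-2-yl. With nothing to point either way, no step beyond the scatter is expected in this assay, and the estimated step is a 1.0-fold higher number from compound 2 to compound 4 (0.01 log units; within the scatter). Compound 4 is therefore expected to give about 2700 nM, within 900 nM to 8500 nM.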

Compound 4, half-maximal inhibitory concentration: 2750 nM
Compound 4: the middle estimate sits 1.0-fold (0.01 log units) below what was measured; low and high end bracket the measured number.
By their numbers in this assay, from the lowest: compounds 2 and 4 (each within the scatter of the next); then compound 1.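

In this assay, phenyl replaces thiophen-2-yl next to the ring nitrogen with a 1.0-fold higher number from compound 2 to compound 4 (0.02 log units; within the scatter). At this position, a six-membered aromatic ring of carbon only therefore reads the same as a five-membered aromatic ring with 1 hetero atom, within the scatter; the earlier step concerned only 3-chlorophenyl and 4-chlorophenyl. No available evidence bears on this result.

Open, going by these compounds, is whether this position tolerates anything other than an aromatic ring, such as an amine, a carboxylic acid or a longer alkyl chain.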